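A few compounds are considered here, and "the series" means these few. Any claim that something is new, unique, unknown or untested is made for them only; others in the source may bear on it.

Compound 3 `O=C(/C=C\c1ccc(O)cc1)O[C@H]1[C@H](O[C@H]2CCCC[C@H]2O)O[C@H](CO)[C@@H](O)[C@@H]1O` is the starting point here. In a functional assay on SK-MEL-2 cells (Homo sapiens) for cytotoxicity, read by sulforhodamine B assay (a lower number here means a stronger inhibitor, a higher number a weaker inhibitor), compound 3 gives only a limit, > 10000 nM. Compound 1 `O=C(/C=C\c1ccc(O)cc1)O[C@@H]1[C@H](O[C@H]2CCCC[C@@H]2O)O[C@H](CO)[C@@H](O)[C@H]1O` likewise gives a limit in this assay, > 10000 nM. Compound 2 `O=C(/C=C\c1ccc(O)cc1)O[C@@H]1[C@H](O[C@@H]2CCCC[C@@H]2O)O[C@H](CO)[C@@H](O)[C@H]1O` also gives a limit, > 10000 nM. The earlier changes of configuration alone, a step that the two limits leave unreadable from compound 1 to compound 2, a step that the two limits leave unreadable from compound 1 to compound 3 and a step that the two limits leave unreadable from compound 2 to compound 3, therefore cannot be sized, because all three values sit at the limit of > 10000 nM in this assay, at which 3 of the 3 values shown sit. Compound 4 `O=C(/C=C/c1ccc(O)cc1)O[C@H]1[C@H](O[C@@H]2CCCC[C@@H]2O)O[C@H](CO)[C@@H](O)[C@@H]1O` is again a change of configuration only: the two compounds have the same atoms and bonds and differ only in configuration as drawn: 3 of 8 stereo elements differ; a stereocentre at a saturated ring carbon is drawn S in compound 3 and R in compound 4; a stereocentre at a saturated ring carbon is drawn R in compound 3 and S in compound 4; a double bond is drawn Z in compound 3 and E in compound 4. Since every measured rearrangement of configuration left the value at the limit, no step beyond the scatter is expected, and the step from compound 3 to compound 4 is estimated as a step that the limit leaves unreadable from compound 3 to compound 4. Compound 4 is expected to give 20000 nM, in the range 5000 nM to 80000 nM.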

Compound 4, half-maximal inhibitory concentration: > 10000 nM
Compound 4 was reported as a limit; the forecaster's own chance of this, stated with the estimate: 85%; the middle value is on the limit's open side.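

In this assay compound 4 gives only a limit, > 10000 nM, so its steps to compound 1, compound 2 and compound 3 cannot be read. Going by these compounds, whether configuration affects cytotoxicity in these four compounds remains open.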